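A few compounds are considered here, and "the series" means these few. Any claim that something is new, unique, unknown or untested is made for them only; others in the source may bear on it.

Of the compounds shown here, two share one core and have been tested for cytotoxicity. Compound 1 `Cc1ccc(-c2cn(/N=C/c3cc4cc(C)ccc4nc3Cl)c(N)n2)cc1` gives 18000 nM in an ADME assay on HUVEC cells (Homo sapiens) for cytotoxicity, read by MTT assay, with a stated time of 48 h; a lower number here means a stronger inhibitor, a higher number a weaker inhibitor. Compound 2 `Nc1nc(-c2ccc3ccccc3c2)cn1/N=C/c1cc2ccccc2nc1Cl` gives 36200 nM in this assay. Its number and that of compound 1 lie within the usual scatter of one another, so the two cannot be set apart. Compound 3 `Cc1ccc2nc(Cl)c(/C=N/n3cc(-c4ccc5ccccc5c4)nc3N)cc2c1` differs from compound 2 by methyl in place of hydrogen on an aromatic carbon. Within the data shown here, no measured pair shows this single change, so the step is expected to be small or none beyond the scatter. Compound 3 is therefore estimated at 32000 nM, between 12000 nM and 80000 nM, a step of a 1.1-fold lower number from compound 2 to compound 3 (0.05 log units; within the scatter).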

Compound 3, half-maximal inhibitory concentration: 11400 nM
For compound 3 the middle estimate is 2.8-fold (0.45 log units) above the measured one; the whole stated range lies above it.
By their numbers in this assay, from the lowest: compounds 3, 1 and 2 (each within the scatter of the next, the first and the last beyond it).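

In this assay, among these compounds, methyl in place of hydrogen on this aromatic carbon of the fused ring system gives a 3.2-fold lower number from compound 2 to compound 3 (0.50 log units; beyond the scatter), the first single change here to pass the scatter. Naphthalen-2-yl in place of 4-methylphenyl, with that methyl present in both compounds, gives a 1.6-fold lower number from compound 1 to compound 3 (0.20 log units; within the scatter), so this second change cannot be told from no change. Nothing available explains the methyl step. Going by these compounds, whether the methyl step would also appear with 4-methylphenyl in place of naphthalen-2-yl remains open. So does what a methoxy group or an amine on the same carbon would do to the number.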